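This account rests on a few compounds, and the source may have more. Where it says the series, first, only, none or still open, it means among the compounds named here.

Among the measured compounds shown here, compound 2 `COC(=O)[C@H](NC(=O)Cn1cc(C2=C(c3c[nH]c4ccccc34)C(=O)N(C)C2=O)c2ccccc21)C(C)C` is one of two compounds measured in a functional assay on HCT-8 cells (Homo sapiens) for cytotoxicity, read by MTT assay, with a stated time of 24 h (on this read-out lower numbers stand for stronger inhibition and higher numbers for weaker inhibition), where compound 2 gives 25800 nM. The other, compound 1 `COC(=O)[C@@H](C)NC(=O)Cn1cc(C2=C(c3c[nH]c4ccccc34)C(=O)N(C)C2=O)c2ccccc21`, gives 21400 nM in this assay, and the two numbers sit together: a 1.2-fold higher number from compound 1 to compound 2 (0.08 log units; within the scatter). Compound 2 therefore stands at one end of a pair whose difference does not exceed the scatter. Compound 3 `COC(=O)C[C@@H](NC(=O)Cn1cc(C2=C(c3c[nH]c4ccccc34)C(=O)N(C)C2=O)c2ccccc21)C(=O)OC` changes compound 2 at the same place once more, with (methoxycarbonyl)methyl in place of isopropyl on a saturated chain carbon bound to an amide-type nitrogen and a carbonyl carbon. For the measured compounds named here, the only step that bears on this is the one from compound 1 to compound 2, which moved the number only within the scatter when the group at this position was exchanged. Going by the values given here, with that as the sole guide, compound 3 is expected to come out close to compound 2, meaning a 1.0-fold lower number from compound 2 to compound 3 (0.01 log units; within the scatter). The estimate for compound 3 in this assay is 25000 nM, with a likely range from 10000 nM to 60000 nM.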

Compound 3, half-maximal inhibitory concentration: 23400 nM
Compound 3: the middle estimate sits 1.1-fold (0.03 log units) above what was measured, and the stated range covers the measured number.
By their numbers in this assay, from the lowest: compounds 1, 3 and 2 (each within the scatter of the next).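

In this assay, (methoxycarbonyl)methyl in place of isopropyl gives a 1.1-fold lower number from compound 2 to compound 3 (0.04 log units; within the scatter), so this position now tolerates more than simple carbon groups: a larger group that carries hydrogen-bond acceptors, which isopropyl lacks, still leaves the number within the scatter. Methoxycarbonyl in place of hydrogen further along the chain, on the saturated chain carbon two bonds from the amide-type nitrogen and the carbonyl carbon, gives a 1.1-fold higher number from compound 1 to compound 3 (0.04 log units; within the scatter), so all three compounds remain level with one another. Nothing available explains why the number stays flat across these changes.

As far as these compounds go, whether any group at this place can move the number beyond the scatter remains open. A free carboxylic acid, an amine or a benzyl group on this carbon would test that, and the three compounds shown cannot predict the outcome.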